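Changing the Nitrooxy Chain of Compound 2

The source may hold more compounds than are shown below. What is called first, only, known or untested is meant among the compounds shown, and "the series" means these compounds.

In a functional assay on NCI-H1792 cells (Homo sapiens) for cytotoxicity, read by resazurin assay, with a stated time of 72 h (a lower number here means a stronger inhibitor, a higher number a weaker inhibitor), compound 1 `COc1cc(/C=C/C(=O)OCCCCCCO[N+](=O)[O-])ccc1O` gives 48700 nM, and compound 2 `COc1cc(/C=C/C(=O)OCCCO[N+](=O)[O-])ccc1O` gives 28500 nM. Among the measured compounds shown here, these are the only two numbers available, and compound 2 stands within the scatter of compound 1. Compound 3 `COc1cc(/C=C/C(=O)OC/C=C/CO[N+](=O)[O-])ccc1O` has not yet been measured. It differs from compound 2 by a group of 7 heavy atoms (3 carbon, 1 nitrogen, 3 oxygen; no ring) in place of a group of 6 heavy atoms (2 carbon, 1 nitrogen, 3 oxygen; no ring), on a saturated chain carbon bound to an oxygen next to a carbonyl group. For the measured compounds named here, only one measured step bears on this change, as it also alters the chain: a 1.7-fold lower number from compound 1 to compound 2 (0.23 log units; within the scatter). Going by the values given here, no measured compound carries the entering group, so this evidence is indirect. Even so, nothing in this assay points to a change beyond the scatter, and no direction is favoured. The estimated step is a 1.1-fold higher number from compound 2 to compound 3 (0.02 log units; within the scatter), which would leave the number essentially unchanged. Compound 3 is expected at 30000 nM, with an estimated range from 14000 nM to 62000 nM.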

Compound 3, half-maximal inhibitory concentration: 4860 nM
Compound 3: the middle estimate sits 6.2-fold (0.79 log units) above what was measured, outside the stated range (below it).
By their numbers in this assay, from the lowest: compound 3; then compounds 2 and 1 (each within the scatter of the next).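

In this assay, the chain position proves responsive to a change: a 5.9-fold lower number from compound 2 to compound 3 (0.77 log units; beyond the scatter) when the 2-(nitrooxy)ethyl group gives way to the entering group, whereas the earlier step between compound 1 and compound 2 stayed within the scatter. The position therefore tolerates a change in saturated chain length without a clear shift in the number, yet a change that also brings in a second double bond outside the aromatic rings moves it beyond the scatter. No evidence is available to explain this difference.

The entering group adds both a carbon and a double bond, and the compounds shown cannot separate these two changes, as none carries a saturated chain of matching size. They also leave open whether the number would hold if a hydroxyl group or a carboxylic acid replaced the nitrooxy end of the unsaturated chain.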